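The source may report more compounds than this note shows. Statements on the series, on what has been measured and on what is new or still open speak of the compounds shown alone.

In a functional assay on Bel7402/5-FU cells (Homo sapiens) for antiproliferative activity, read by MTT assay, with a stated time of 72 h (a higher number here means a weaker inhibitor, a lower number a stronger inhibitor), compound 1 `C=C1C(=O)O[C@H]2[C@H]1CC/C(Cn1cc(Cn3cc(F)c(=O)[nH]c3=O)nn1)=C\CC[C@@]1(C)O[C@@H]21` gives > 20000 nM, which is a limit of the assay. Compound 2 `C=C1C(=O)O[C@H]2[C@H]1CC/C(COC(=O)CCC(=O)NCCCCCCNC(=O)Cn1cc(F)c(=O)[nH]c1=O)=C\CC[C@@]1(C)O[C@@H]21` gives > 20000 nM, likewise a limit and not a number. Compound 3 `C=C1C(=O)O[C@H]2[C@H]1CC/C(Cn1cc(Cn3cc(F)c(=O)n(Cc4ccc(F)cc4)c3=O)nn1)=C\CC[C@@]1(C)O[C@@H]21` gives 4860 nM. Compound 2 thus stands at the limit of > 20000 nM in this assay, at which 2 of the 3 values shown sit, with no number of its own to step from.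

The change to compound 4 `C=C1C(=O)O[C@H]2[C@H]1CC/C(COC(=O)CCC(=O)NCCCCCCNC(=O)Cn1cc(F)c(=O)n(Cc3ccccc3)c1=O)=C\CC[C@@]1(C)O[C@@H]21` is benzyl in place of hydrogen on an aromatic nitrogen. Among the measured compounds shown here, one measured step bears on it: an at least 4.1-fold lower number from compound 1 to compound 3 (0.61 log units; beyond the scatter), beyond the scatter, with 4-fluorobenzyl in place of hydrogen on an aromatic nitrogen. That step carries a fluoro group that benzyl lacks, and its chain differs from the chain of compound 2, so it is only a loose guide. On the evidence of an at least 4.1-fold lower number from compound 1 to compound 3 (0.61 log units; beyond the scatter), a step of similar size towards a lower number in this assay is expected. The expected step is an at least 2.8-fold lower number from compound 2 to compound 4 (0.45 log units; beyond the scatter). For compound 4 the estimate is 7000 nM, with an expected range of 2500 nM to 20000 nM.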

Compound 4, half-maximal inhibitory concentration: 16200 nM
Estimate against measurement, compound 4: 2.3-fold (0.36 log units) below; the range from low to high includes it.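

In this assay, the new step is an at least 1.2-fold lower number from compound 2 to compound 4 (0.09 log units; that floor lies within the scatter), so benzyl on this aromatic nitrogen turns a compound without a number of its own into one with a measured value. Compound 2 stands at a limit, not a number, so the true size of the step stays unfixed: the limit of > 20000 nM in this assay, at which 2 of the 4 values shown sit.

Replacing hydrogen on this nitrogen now brings a measurable value on two different chains, in the steps to compound 3 and to compound 4, and no compound shown goes against this.

Still open, on these data alone, is whether a carboxylic acid, an amine or a longer chain on this nitrogen would give a lower number than benzyl. As far as these compounds go, it is also open whether 4-fluorobenzyl in place of benzyl would do so on the chain of compound 4.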